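The compounds below may be only part of what the source reports. "The series", "measured", "known", "first", "only" and "open" are said of these compounds alone.

Measured so far in an assay on isolated protein for displacement of a labelled ligand from Apoptosis regulator Bcl-2 (Homo sapiens), with a stated time of 15 min; on this read-out lower numbers stand for stronger inhibition and higher numbers for weaker inhibition:
compound 1, `COc1ccc(C2=C(CN3CCN(c4ccc(C(=O)NS(=O)(=O)c5ccc(NCC6CCOCC6)c([N+](=O)[O-])c5)c(Oc5cnc6[nH]ccc6c5)c4)CC3)CCC(C)(C)C2)cc1`, 3.8 nM
compound 2, `CC1(C)CCC(CN2CCN(c3ccc(C(=O)NS(=O)(=O)c4ccc(NCC5CCOCC5)c([N+](=O)[O-])c4)c(Oc4cnc5[nH]ccc5c4)c3)CC2)=C(c2ccccc2C(F)(F)F)C1`, 1.7 nM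
compound 3, `CN(C)CCCNc1ccc(S(=O)(=O)NC(=O)c2ccc(N3CCN(CC4=C(c5ccc(C(F)(F)F)cc5)CC(C)(C)CC4)CC3)cc2Oc2cnc3[nH]ccc3c2)cc1[N+](=O)[O-]`, 0.89 nM

All three share one core and differ only at its edges. Among the compounds with values here, the one single-point step among them, a 2.2-fold lower number from compound 1 to compound 2 (0.35 log units; beyond the scatter), concerns the aryl group on the double-bonded ring carbon and shows a modest gain. Compound 3 gives the lowest number of the three, but its gap to compound 2 lies within the scatter, so no order between those two can be read; only its gap to compound 1 is beyond the scatter.

Compound 4, `CC1(C)CCC(CN2CCN(c3ccc(C(=O)NS(=O)(=O)c4ccc(OC5CCOCC5)c([N+](=O)[O-])c4)c(Oc4cnc5[nH]ccc5c4)c3)CC2)=C(c2ccc(C(F)(F)F)cc2)C1`, differs from compound 3 in one place: (oxan-4-yl)oxy in place of (3-(dimethylamino)propyl)amino on an aromatic carbon. Within the data shown here, no measured step touches this position, so nothing already known speaks directly for or against the change. Compounds 1 and 2 carry yet another group at the same place and still give numbers close to compound 3, which suggests that this end of the molecule tolerates variation. The step expected in this assay is therefore small, a 1.7-fold higher number from compound 3 to compound 4 (0.23 log units; within the scatter), with no direction beyond the scatter. Compound 4 is estimated at 1.5 nM, within a range from 0.5 nM to 5 nM.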

Compound 4, half-maximal inhibitory concentration: 8.4 nM
For compound 4 the middle estimate is 5.6-fold (0.75 log units) below the measured one, and the stated range ends below it.
By their numbers in this assay, from the lowest: compounds 3 and 2 (each within the scatter of the next); then compound 1; then compound 4.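

In this assay, within the data shown here, the exchange gives a 9.4-fold higher number from compound 3 to compound 4 (0.97 log units; beyond the scatter) and so provides the first measured step at this aromatic carbon, ortho to a nitro group, showing that the group it carries can shift the number beyond the scatter. The two groups match in some simple counts, with 7 heavy atoms and 2 hydrogen-bond acceptors each, so those counts alone do not separate them; they differ in that (oxan-4-yl)oxy has one six-membered non-aromatic ring and 0 hydrogen-bond donors, whereas (3-(dimethylamino)propyl)amino has no ring and 1 hydrogen-bond donor, and the heteroatoms also change from nitrogen to oxygen. No available measurement connects the step to any one of these differences.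

The compounds shown leave open which part of the exchange matters, the ring, the oxygen link to the aromatic carbon, or the loss of the dimethylamino group. An (oxan-4-yl)amino group, which keeps the ring with a nitrogen link, and a 3-(dimethylamino)propoxy chain, which keeps the chain with an oxygen link, would help to pull these apart.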